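The source may hold more compounds than are shown below. What is called first, only, known or untested is meant among the compounds shown, and "the series" means these compounds.

Measured in a functional assay (mast cells) for inhibition, with Rattus norvegicus as the target; a higher number here means that more compound is needed for the effect, a lower number that less compound is needed:
- compound 1 `CC1CC/C(=N\Nc2ccc(F)cc2)c2ncc(C(=O)O)c(=O)n21`: 1200 nM
- compound 2 `Cc1ccc(N/N=C2\CCC(C)n3c2ncc(C(=O)O)c3=O)cc1`: 280 nM

Among the measured compounds shown here, compound 2, at 280 nM, holds the lower of the two numbers, and compound 1 is its only neighbour. The next structure is compound 3 `CC1CC/C(=N\Nc2ccc([N+](=O)[O-])cc2)c2ncc(C(=O)O)c(=O)n21`, which carries nitro in place of methyl on an aromatic carbon, para to a large group (nitro in place of methyl on an aromatic carbon). For the measured compounds named here, one measured step bears on this change: a 4.3-fold lower number from compound 1 to compound 2 (0.63 log units; beyond the scatter), a modest step that also exchanges methyl and another group on an aromatic carbon. Going by the values given here, no nitro compound has been measured, so the evidence is thin. Among the compounds with values here, the only compound without the methyl, compound 1, stands higher at 1200 nM, so a step of similar size towards a higher number is expected. The estimated step is a 2.5-fold higher number from compound 2 to compound 3 (0.40 log units; beyond the scatter). Compound 3 is expected at 700 nM, with an estimated range of 150 nM to 3000 nM.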

Compound 3, half-maximal effective concentration: 8900 nM
The estimate for compound 3 lay 13-fold (1.10 log units) below the measured number, outside the stated range (above it).
By their numbers in this assay, from the lowest: compound 2; then compound 1; then compound 3.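

Among the compounds shown here, the aromatic carbon para to a large group proved far more sensitive to substitution than the first pair of compounds indicated: in this assay the exchange of methyl for nitro gave a 32-fold higher number from compound 2 to compound 3 (1.50 log units; beyond the scatter), a large step, whereas the earlier difference between fluoro and methyl was modest. Nitro also separated from fluoro, with a 7.4-fold higher number from compound 1 to compound 3 (0.87 log units; beyond the scatter), so the three compounds ran methyl, fluoro, nitro from the lowest number to the highest, each step beyond the scatter. No measurement shown here accounts for the size of the nitro step.

Open, on these data alone, is where an amine, a methoxy group or a nitrile on the same aromatic carbon would fall in this order. Also open, as far as these compounds go, is whether an unsubstituted ring carbon would sit nearer compound 2 or compound 3.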